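Adding a Chlorine to Compound 3: What to Expect

A few compounds are considered here, and "the series" means these few. Any claim that something is new, unique, unknown or untested is made for them only; others in the source may bear on it.

Of the compounds shown here, three sharing one core have been tested in a functional assay on SW480 cells (Homo sapiens) for antiproliferative activity, read by MTT assay, with a stated time of 72 h; a higher number here means a weaker inhibitor, a lower number a stronger inhibitor. Compound 1 `O=c1c(CSC(=S)N2CCOCC2)coc2cc(Cl)ccc12` gives 6200 nM. Compound 2 `O=c1c(CSC(=S)N2CCCCC2)coc2cc(Cl)ccc12` gives 790 nM. Compound 3 `CC(C)N(C(=S)SCc1coc2ccccc2c1=O)C(C)C` gives 6800 nM. Among these three numbers compound 3 stands highest, though its gap to compound 1 lies within the scatter of the measurement, while compound 2 sits clearly lower. Among the compounds with values here, the single step that can be traced between measured compounds, a 7.8-fold lower number from compound 1 to compound 2 (0.89 log units; beyond the scatter), swaps one ring on the thiocarbonyl carbon for another and says nothing about the aromatic part of the core.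

Compound 4 `CC(C)N(C(=S)SCc1coc2cc(Cl)ccc2c1=O)C(C)C` differs from compound 3 only in that (chloro in place of hydrogen on an aromatic carbon). Within the data shown here, compounds 1 and 2 already carry that chloro, and compound 3 lacks it, but no measured pair differs by the chloro alone, so the data offer no step that bears directly on this change. Compound 1, which carries the chloro alongside a different ring, sits within the scatter of compound 3, which is the only hint that the chlorine by itself need not shift the number much. Compound 4 is therefore expected to land close to compound 3, with a 1.5-fold lower number from compound 3 to compound 4 (0.18 log units; within the scatter) expected to stay within the scatter. The estimate for compound 4 is 4500 nM, ranging from 1500 nM to 13000 nM.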

Compound 4, half-maximal inhibitory concentration: > 25000 nM
Compound 4: no number, only a limit; the forecaster's own chance of this, stated with the estimate: 5%; middle value at least 5.5-fold (0.74 log units) away from the limit.
By their numbers in this assay, from the lowest: compound 2; then compounds 1 and 3 (each within the scatter of the next). At a limit, above all of these: compound 4.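

In this assay compound 4 gives > 25000 nM, which is a limit of the assay and not a number. On this aromatic carbon, meta to a fused ring and para to a fused ring, the data now hold a direct step for chloro in place of hydrogen, and with diisopropylamino on the thiocarbonyl carbon the change is not silent: it gives an at least 3.6-fold higher number from compound 3 to compound 4 (0.56 log units; beyond the scatter). With the chloro present on both sides, the group on the thiocarbonyl carbon also counts, since diisopropylamino in place of piperidin-1-yl gives an at least 31-fold higher number from compound 2 to compound 4 (1.50 log units; beyond the scatter), and diisopropylamino in place of morpholin-4-yl gives an at least 4.0-fold higher number from compound 1 to compound 4 (0.60 log units; beyond the scatter).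

From the compounds shown here alone, the true size of these steps stays open, because the reading for compound 4 stops at a limit: the limit of > 25000 nM in this assay, at which 1 of the 4 values shown sits. Also open is whether the chloro step would hold with piperidin-1-yl or morpholin-4-yl on the thiocarbonyl carbon, and whether fluoro, a methoxy group or an amine on the same aromatic carbon would behave as chloro does.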